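The source may hold more compounds than are shown below. What is called first, only, known or untested is meant among the compounds shown, and "the series" means these compounds.

Three compounds sharing one core were tested in a functional assay on the whole organism with Rattus norvegicus as the target; a lower number here means that less compound is needed, a higher number that more compound is needed for the effect. Compound 1 `Nc1nc2cc(OC(F)(F)F)ccc2s1` reached only the limit of the assay, > 10 mg/kg. Compound 2 `Nc1nc2cccc(OC(F)(F)F)c2s1` likewise gave only the limit, > 10 mg/kg. Within the data shown here, compound 3 `Cn1c(=N)sc2cc(OC(F)(F)F)ccc21` is the one compound with an actual number, 5 mg/kg. The other two values stand at the limit of > 10 mg/kg in this assay, at which 2 of the 3 values shown sit. Compound 4 `CCSCCn1c(=N)sc2cc(OC(F)(F)F)ccc21` has not yet been measured. It differs from compound 3 by (ethylsulfanyl)methyl in place of hydrogen on a saturated chain carbon bound to an aromatic nitrogen. Among the measured compounds shown here, with no measured pair of this kind to lean on, a step within the scatter and in no firm direction is expected, which puts no change at the digits printed from compound 3 to compound 4 (within the scatter) as the estimated change. Compound 4 is therefore estimated at 5 mg/kg, within a range from 2 mg/kg to 15 mg/kg.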

Compound 4, dose for half-maximal effect: 2.2 mg/kg
Estimate against measurement, compound 4: 2.3-fold (0.36 log units) above; the range from low to high includes it.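

Putting (ethylsulfanyl)methyl in place of hydrogen on a saturated chain carbon bound to an aromatic nitrogen gives a 2.3-fold lower number from compound 3 to compound 4 (0.36 log units; beyond the scatter). This position therefore takes a longer, sulfur-bearing chain without losing the effect, and the step is modest but real. The values shown do not say why the number falls. Whether the sulfur itself matters stays open, since the compounds shown include no all-carbon chain of similar length to compare. As far as these compounds go, how a chain ending in an amine or a carboxylic acid would behave at this position also stays open.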